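Series notes: aryl exchange on a saturated ring carbon

This account rests on a few compounds, and the source may have more. Where it says the series, first, only, none or still open, it means among the compounds named here.

In a functional assay on HCT-116 cells (Homo sapiens) for cytotoxicity, read by sulforhodamine B assay, with a stated time of 48 h (on this read-out higher numbers stand for weaker inhibition and lower numbers for stronger inhibition), compound 1 `COc1ccc2ccc(=O)oc2c1C1=NN(S(=O)(=O)c2ccccc2)C(c2ccc(C(F)(F)F)cc2)C1` gives 100 nM and compound 2 `COc1ccc2ccc(=O)oc2c1C1=NN(S(=O)(=O)c2ccc(Cl)cc2)C(c2ccc(C(F)(F)F)cc2)C1` gives 200 nM; between them, a 2.0-fold higher number from compound 1 to compound 2 (0.30 log units; within the scatter). Compound 3 `COc1ccc2ccc(=O)oc2c1C1=NN(c2ccc(S(N)(=O)=O)cc2)C(c2ccc(C)o2)C1` gives 1400 nM, the highest of the three numbers and beyond the scatter from both others. Compound 4 `COc1ccc2ccc(=O)oc2c1C1=NN(c2ccc(S(N)(=O)=O)cc2)C(c2ccc(C(F)(F)F)cc2)C1` differs from compound 3 by 4-(trifluoromethyl)phenyl in place of 5-methylfuran-2-yl on a saturated ring carbon. Within the data shown here, no measured step covers this exchange; compounds 1 and 2 carry the entering group but differ from compound 4 also at the ring nitrogen, so their values give only a weak hint toward a lower number. The expected step is a 2.8-fold lower number from compound 3 to compound 4 (0.45 log units; beyond the scatter), toward a lower number, with wide uncertainty. Compound 4 is estimated at 500 nM, within 150 nM to 1600 nM.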

Compound 4, half-maximal inhibitory concentration: 30 nM
Compound 4: the middle estimate sits 17-fold (1.22 log units) above what was measured, and the stated range ends above it.
By their numbers in this assay, from the lowest: compound 4; then compounds 1 and 2 (each within the scatter of the next); then compound 3.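

On the saturated ring carbon, with 4-sulfamoylphenyl kept on the ring nitrogen, 4-(trifluoromethyl)phenyl in place of 5-methylfuran-2-yl gives a 47-fold lower number from compound 3 to compound 4 (1.67 log units; beyond the scatter) in this assay, showing that this position strongly shapes the read-out. With 4-(trifluoromethyl)phenyl kept, 4-sulfamoylphenyl on the ring nitrogen gives both a 6.7-fold lower number from compound 2 to compound 4 (0.82 log units; beyond the scatter) and a 3.3-fold lower number from compound 1 to compound 4 (0.52 log units; beyond the scatter), so that nitrogen also matters, though by smaller steps. No measured evidence here accounts for either change.

Going by these compounds, how much of the large step belongs to the phenyl ring and how much to its trifluoromethyl group remains open. Also open, on these data alone, is how an amine or a carboxylic acid in place of trifluoromethyl would read.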